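A few compounds are considered here, and "the series" means these few. Any claim that something is new, unique, unknown or untested is made for them only; others in the source may bear on it.

Measured so far in an assay on membranes from HeLa cells for displacement of a labelled ligand from adenosine receptor A3 (Homo sapiens), read by scintillation counting, with a stated time of 180 min, tested at 1 uM; on this read-out higher numbers stand for more inhibition at the one concentration tested (going by the name of the read-out) and lower numbers for less inhibition:
compound 1 `CC1=C(C(=O)CC(C)C)C(c2cccs2)NC(=O)N1` gives 18%;
compound 2 `CC1=C(C(=O)CC(C)C)C(c2ccsc2)NC(=O)N1` gives 14%;
compound 3 `CC1=C(c2ncc(C)o2)C(c2cccs2)NC(=O)N1` gives 1%.

The change thiophen-3-yl in place of thiophen-2-yl on a saturated ring carbon gave a number 4 percentage points lower from compound 1 to compound 2 (within the scatter). The change 5-methyl-1,3-oxazol-2-yl in place of isobutylcarbonyl on a double-bonded ring carbon gave a number 17 percentage points lower from compound 1 to compound 3 (beyond the scatter), leaving compound 3 the lowest of the three in this assay. Compound 4 `CC1=C(c2ncc(C)o2)C(c2ccsc2)NC(=O)N1` is not yet measured. It carries the change (thiophen-3-yl in place of thiophen-2-yl on a saturated ring carbon), the same kind of change as the one above, though here the saturated ring carbon is next to the ring atom that bears a 5-methyl-1,3-oxazol-2-yl group rather than an isobutylcarbonyl group. Because the earlier step of this kind was a number 4 percentage points lower from compound 1 to compound 2 (within the scatter), the expected step is a number 1 percentage points lower from compound 3 to compound 4 (within the scatter). Compound 4 is therefore estimated to give 0% in this assay, expected between -10% and 12%.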

Compound 4, a percentage reported as inhibition, at one concentration (the size of the read-out at that concentration, not a potency): 2%
The estimate for compound 4 lay 2 percentage points below the measured number; measured number inside the range.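

In this assay, thiophen-3-yl in place of thiophen-2-yl gave a number 1 percentage points higher from compound 3 to compound 4 (within the scatter), so the change made no clear difference on either core: the same change on two cores in this assay, a number 4 percentage points lower (within the scatter) from compound 1 to compound 2 and a number 1 percentage points higher (within the scatter) from compound 3 to compound 4, 5 percentage points apart, within the scatter of two such steps. 5-Methyl-1,3-oxazol-2-yl in place of isobutylcarbonyl gave a number 12 percentage points lower from compound 2 to compound 4 (beyond the scatter), so the drop carried over from the thiophen-2-yl compounds to the thiophen-3-yl compounds: the same change on two cores in this assay, a number 17 percentage points lower (beyond the scatter) from compound 1 to compound 3 and a number 12 percentage points lower (beyond the scatter) from compound 2 to compound 4, 5 percentage points apart, within the scatter of two such steps. This rests on only four compounds at one concentration, so it does not show that either change would behave the same way on other cores, or how potency would change.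

Going by these compounds, it remains open how an acetyl group or a primary amide would read in place of these two groups. On these data alone, a phenyl ring in place of the thiophene is equally open.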